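Replacing the Ester of Compound 1 with a Urea

A few compounds are considered here, and "the series" means these few. Any claim that something is new, unique, unknown or untested is made for them only; others in the source may bear on it.

Compound 1 `CCOC(=O)c1cccc(-c2ccc(OCC)cc2)c1` gives 87% in an assay on COS-7 cells for inhibition of patatin-like phospholipase domain-containing protein 2 (Mus musculus), tested at 200 uM (on this read-out higher numbers stand for more inhibition at the one concentration tested (going by the name of the read-out) and lower numbers for less inhibition), the highest of the three numbers recorded. Compound 2 `CCOC(=O)c1cccc(-c2ccc(CN(C)C)cc2)c1` gives 67%, and compound 3 `CCCCCCOC(=O)c1cccc(-c2ccc(OCC)cc2)c1` gives 48%. The step of a number 20 percentage points lower from compound 1 to compound 2 (beyond the scatter) follows the change of (dimethylamino)methyl in place of ethoxy on an aromatic carbon, while the step of a number 39 percentage points lower from compound 1 to compound 3 (beyond the scatter) follows butyl in place of hydrogen on a saturated chain carbon, two bonds along the chain from an oxygen next to a carbonyl group.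

Compound 4 `CCOc1ccc(-c2cccc(NC(=O)N(C)C)c2)cc1` differs from compound 1 by (dimethylcarbamoyl)amino in place of ethoxycarbonyl on an aromatic carbon. Among the compounds with values here, no measured step exchanges the ethoxycarbonyl group itself, so the closest guide is the step to compound 3, where enlarging that same group cost a number 39 percentage points lower from compound 1 to compound 3 (beyond the scatter). Both measured changes lowered inhibition, and a larger change at the ester end is therefore expected to lower it as well, though with wide uncertainty. Compound 4 is estimated at 50%, within 20% to 80%, a step of a number 37 percentage points lower from compound 1 to compound 4 (beyond the scatter) expected.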

Compound 4, a percentage reported as inhibition, at one concentration (the size of the read-out at that concentration, not a potency): 68%
Beside the measured number, compound 4's estimate is 18 percentage points below it; the range from low to high includes it.
By their numbers in this assay, from the lowest: compound 3; then compounds 2 and 4 (each within the scatter of the next); then compound 1.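

In this assay, putting (dimethylcarbamoyl)amino in place of ethoxycarbonyl on this aromatic carbon gives a number 19 percentage points lower from compound 1 to compound 4 (beyond the scatter), so inhibition at this concentration does not depend on an ester at this position, although the ester of compound 1 gives the higher number. The printed values also separate two changes at this position: compound 3, which keeps the ester but carries an added butyl, gives 48%, whereas compound 4 gives 68%. Nothing available explains the drop from the ester to the urea.

The compounds shown leave open whether the hydrogen on the urea nitrogen or the two methyl groups matter. They also leave open how a carboxylic acid, a simple amine or a urea with a longer chain would fare at this position.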